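The source may report more compounds than this note shows. Statements on the series, on what has been measured and on what is new or still open speak of the compounds shown alone.

Compound 2 `CCOC(=O)C1CCN(CCCOc2cc3ncnc(Nc4ccc(C#N)cc4)c3cc2OC)CC1` gives 57700 nM in a functional assay on HepG2 cells (Homo sapiens) for antiproliferative activity, read by MTT assay, with a stated time of 72 h; on this read-out lower numbers stand for stronger inhibition and higher numbers for weaker inhibition. On the two numbers in hand it carries the numerically lower value, but compound 1 `CCN(CC)CCCOc1cc2ncnc(Nc3ccc(C#N)cc3)c2cc1OC` at 59400 nM sits within the scatter of it, the pair being separated by a 1.0-fold lower number from compound 1 to compound 2 (0.01 log units; within the scatter). Compound 3 `COc1cc2c(Nc3ccc(C#N)cc3)ncnc2cc1OCCCN1CCc2ccccc2C1` is next in line; relative to compound 2 the change is 1,2,3,4-tetrahydroisoquinolin-2-yl in place of 4-(ethoxycarbonyl)piperidin-1-yl on a saturated chain carbon, three bonds along the chain from an oxygen on an aromatic ring. Among the compounds with values here, the only measured step that bears on this position is a 1.0-fold lower number from compound 1 to compound 2 (0.01 log units; within the scatter), an exchange of one amine for another at the same chain terminus, which moved nothing beyond the scatter. Two different terminal amines thus gave indistinguishable numbers, and the tetrahydroisoquinoline is a third variant at the same place; the expectation for this assay is therefore no shift beyond the scatter, a step of a 1.0-fold lower number from compound 2 to compound 3 (0.02 log units; within the scatter). Compound 3 is estimated at 55000 nM, with a range from 25000 nM to 120000 nM.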

Compound 3, half-maximal inhibitory concentration: > 100000 nM
Compound 3: only a limit was reported (the forecaster's own chance of this, stated with the estimate: 15%); middle value at least 1.8-fold (0.25 log units) from the limit.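

In this assay compound 3 is reported only as a limit, not as a number: the limit of > 100000 nM in this assay, at which 1 of the 3 values shown sits.

With 1,2,3,4-tetrahydroisoquinolin-2-yl at this chain carbon the steps read an at least 1.7-fold higher number from compound 2 to compound 3 (0.23 log units; that floor lies within the scatter) and an at least 1.6-fold higher number from compound 1 to compound 3 (0.22 log units; that floor lies within the scatter), so a real loss against either earlier terminal amine is not established, and no gain is seen. Within the data shown here, what is new is that this group, the first here to carry a six-membered aromatic ring of carbon only, is the first to return a limit, which leaves the full size of both steps unknown.

As far as these compounds go, whether a morpholine or piperazine at the chain end, a free carboxylic acid in place of the ethyl ester, or a longer chain would move the number beyond the scatter stays open. No terminal group shown so far gives a step that is clearly beyond the scatter.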